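From Iodo to Trifluoromethyl on the Aromatic Ring

This account rests on a few compounds, and the source may have more. Where it says the series, first, only, none or still open, it means among the compounds named here.

Compound 3 `O=C1C(Nc2ccc(I)cc2)=CC(=O)c2ncccc21` holds the highest of the three numbers in a functional assay on the whole organism (aorta) with Rattus norvegicus as the target (on this read-out higher numbers stand for larger maximal responses and lower numbers for smaller maximal responses), with 89%, while compound 2 `O=C1C(Nc2ccc(Cl)cc2)=CC(=O)c2ncccc21` gives 86% and compound 1 `O=C1C(Nc2ccc(F)cc2)=CC(=O)c2ncccc21` gives 79%, both within the scatter of it. The steps of a number 7 percentage points higher from compound 1 to compound 2 (within the scatter), a number 10 percentage points higher from compound 1 to compound 3 (within the scatter) and a number 3 percentage points higher from compound 2 to compound 3 (within the scatter) show that swapping one halogen for another on this aromatic carbon left the maximal response within the scatter each time. Compound 4 `O=C1C(Nc2ccc(C(F)(F)F)cc2)=CC(=O)c2ncccc21` differs from compound 3 by trifluoromethyl in place of iodo on an aromatic carbon. For the measured compounds named here, no measured step brings in a four-heavy-atom group at this place, so the halogen steps bear on it only loosely; no change beyond the scatter is expected in this assay. Compound 4 is expected to give 85%, between 72% and 96%. The expected step is a number 4 percentage points lower from compound 3 to compound 4 (within the scatter).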

Compound 4, largest response reached (Emax), in percent of the reference or control that the assay uses: 91%
The estimate for compound 4 lay 6 percentage points below the measured number, within the range that was stated.
By their numbers in this assay, from the lowest: compounds 1, 2, 3 and 4 (each within the scatter of the next, the first and the last beyond it).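

In this assay, trifluoromethyl on this aromatic carbon stays within the scatter of the iodo and chloro compounds, with a number 2 percentage points higher from compound 3 to compound 4 (within the scatter) and a number 5 percentage points higher from compound 2 to compound 4 (within the scatter). For the compounds shown here, only the comparison with fluoro goes beyond the scatter, with a number 12 percentage points higher from compound 1 to compound 4 (beyond the scatter), the first such step at this position, though a modest one. Nothing given here accounts for these steps. Still open, on these data alone, is how an amine or a carboxylic acid on this aromatic carbon would compare with these halogen and trifluoromethyl compounds.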